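Urea to Carbamate on the Shared Core: Expected Cytotoxicity

The source may report more compounds than this note shows. Statements on the series, on what has been measured and on what is new or still open speak of the compounds shown alone.

Compound 1 `CCCCNC(=O)Nc1cc2nc(C3CCCCC3)[nH]c2cc1N(CC)CC` was tested in an ADME assay on Vero cells (Chlorocebus sabaeus) for cytotoxicity, read by resazurin assay, with a stated time of 3 days; on this read-out lower numbers stand for stronger inhibition and higher numbers for weaker inhibition. In this assay compound 1 gives > 100 ug/mL, which is a limit of the assay rather than a number. Compound 2 `CCCNC(=O)Nc1cc2nc(C3CCCCC3)[nH]c2cc1N1CCCC1` gives > 100 ug/mL in this assay, also a limit. Going by the values given here, both values sit at the limit of > 100 ug/mL in this assay, at which 2 of the 2 values shown sit, so no measured step is known. Compound 3 `CCCCOC(=O)Nc1cc2nc(C3CCCCC3)[nH]c2cc1N(CC)CC` carries butoxy in place of butylamino on a carbonyl carbon relative to compound 1. Because compound 1 rests at the limit of > 100 ug/mL in this assay, at which 2 of the 2 values shown sit, the step that the limit leaves unreadable from compound 1 to compound 3 is expected to stay within the usual scatter. Compound 3 is therefore expected to give 120 ug/mL in this assay, within 50 ug/mL to 300 ug/mL.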

Compound 3, half-maximal inhibitory concentration: > 100 ug/mL
Compound 3: a limit, no number; the forecaster's own chance of this, stated with the estimate: 75%; the middle value does not contradict the limit.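

No step can be read from compound 1 to compound 3 in this assay, because both compounds rest at a limit of the assay: the limit of > 100 ug/mL in this assay, at which 3 of the 3 values shown sit. What stays open is the concentration at which any of the compounds shown reaches half-maximal inhibition, and so whether butoxy and butylamino differ at all.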